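The source may report more compounds than this note shows. Statements on the series, on what has been measured and on what is new or still open speak of the compounds shown alone.

Measured so far: compound 1 `c1ccc(CCc2cccc(N3CCNCC3)n2)cc1`, compound 2 `CCCCCCCCCc1cccc(N2CCNCC2)n1` and compound 3 `CCCCCCCCCCc1cccc(N2CCNCC2)n1`.

In a functional assay on the whole organism with Mus musculus as the target, in the maximal electroshock model, with a stated time of 120 min (a lower number here means that less compound is needed, a higher number that more compound is needed for the effect), compound 2 gives 10 mg/kg and compound 3 gives 30 mg/kg. Compound 1 gives only a limit, > 300 mg/kg, in this assay. Compound 3 therefore stands highest of the two numbers, with compound 2 nearest: a 3.0-fold higher number from compound 2 to compound 3 (0.48 log units; beyond the scatter). Compound 4 `CCCCCc1cccc(N2CCNCC2)n1` differs from compound 3 by hydrogen in place of pentyl on a saturated chain carbon, five bonds along the chain from an aromatic carbon. Both measured steps altered the chain: an at least 30-fold lower number from compound 1 to compound 2 (1.47 log units; beyond the scatter) was large, while a 3.0-fold higher number from compound 2 to compound 3 (0.48 log units; beyond the scatter) was modest. Going by the values given here, removing a pentyl has no direct precedent here, so a step beyond the scatter in either direction is possible. Compound 4 is expected to give 30 mg/kg, within 10 mg/kg to 100 mg/kg, which means an expected step of no change at the digits printed from compound 3 to compound 4 (within the scatter).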

Compound 4, minimum effective dose: 10 mg/kg
Compound 4: the middle estimate sits 3.0-fold (0.48 log units) above what was measured; the range from low to high includes it.
By their numbers in this assay, from the lowest: compounds 2 and 4 (each within the scatter of the next); then compound 3. At a limit, above all of these: compound 1.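

In this assay hydrogen in place of pentyl, five bonds along the chain from an aromatic carbon, gives a 3.0-fold lower number from compound 3 to compound 4 (0.48 log units; beyond the scatter) and so the chain can lose this much with no cost, while no change at the digits printed from compound 2 to compound 4 (within the scatter) places the shorter chain level with compound 2. Propyl in place of phenyl gives an at least 30-fold lower number from compound 1 to compound 4 (1.47 log units; beyond the scatter) and so the drop from compound 1 does not need the longer chain of compound 2. Compound 1 is a limit: the limit of > 300 mg/kg in this assay, at which 1 of the 4 values shown sits.

From the compounds shown here alone, whether a chain shorter still, such as ethyl or methyl, holds this level remains open. So does the effect of an amine or a carboxylic acid at the chain end.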